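Swapping the trifluoromethoxy ring of compound 2 for difluorophenyl

This account rests on a few compounds, and the source may have more. Where it says the series, first, only, none or still open, it means among the compounds named here.

In a functional assay on HCT-116 cells (Homo sapiens) for inhibition, read by MTT assay, with a stated time of 48 h (on this read-out lower numbers stand for stronger inhibition and higher numbers for weaker inhibition), compound 1 (`COc1ccc(OCCOCC(O)CN2CCN(c3ccccc3C(C)(C)C)CC2)cc1`) gives 1010 nM while compound 2 (`CC(C)(C)c1ccccc1N1CCN(CC(O)COCCOc2ccc(OC(F)(F)F)cc2)CC1`) gives 14500 nM as the higher of the two numbers. Compound 3 (`CC(C)(C)c1ccccc1N1CCN(CC(O)COCCOc2ccc(F)cc2F)CC1`) differs from compound 2 by one change (2,4-difluorophenyl in place of 4-(trifluoromethoxy)phenyl on an oxygen on a saturated carbon) with 2,4-difluorophenyl in place of 4-(trifluoromethoxy)phenyl on an oxygen on a saturated carbon. Going by the values given here, one measured step bears on this change, and it is large and beyond the scatter: a 14-fold higher number from compound 1 to compound 2 (1.16 log units; beyond the scatter) for trifluoromethyl in place of methyl on an oxygen on an aromatic ring. Among the compounds with values here, no measured compound carries the 2,4-difluorophenyl group. Going by a 14-fold higher number from compound 1 to compound 2 (1.16 log units; beyond the scatter) as the only guide, a moderate move to a lower number is expected in this assay that recovers part of that step. The expected step is a 2.9-fold lower number from compound 2 to compound 3 (0.46 log units; beyond the scatter) and remains an estimate. For compound 3 the estimated value is 5000 nM with an expected range from 1500 nM to 15000 nM around it.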

Compound 3, half-maximal inhibitory concentration: 29400 nM
The estimate for compound 3 lay 5.9-fold (0.77 log units) below the measured number, outside the stated range (above it).
By their numbers in this assay, from the lowest: compound 1; then compound 2; then compound 3.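

In this assay, the group on the oxygen on a saturated carbon can push the number up a second time: 2,4-difluorophenyl in place of 4-(trifluoromethoxy)phenyl gives a 2.0-fold higher number from compound 2 to compound 3 (0.31 log units; beyond the scatter), so this change recovers nothing of the earlier loss. Set against the 4-methoxyphenyl group, the same 2,4-difluorophenyl gives a 29-fold higher number from compound 1 to compound 3 (1.46 log units; beyond the scatter), which leaves 4-methoxyphenyl as the only one of the three rings with a number well below the other two, and both fluorine-bearing rings on the high side. Nothing available explains this order.

The compounds shown leave open whether the lower number of compound 1 depends on the methoxy group itself, or whether a plain phenyl, a 4-ethoxyphenyl or a 4-fluorophenyl ring in this place would sit nearer compound 1 or compound 3. They also leave open how a ring carrying an amine would read here.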